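The compounds below may be only part of what the source reports. "The series", "measured", "known", "first", "only" and "open" are said of these compounds alone.

Measured so far in a functional assay on THP-1 cells (Homo sapiens) for inhibition, read by sulforhodamine B assay, with a stated time of 48 h, tested at 50 uM; a higher number here means more inhibition of growth at the concentration tested, a lower number less inhibition of growth
Compound 1 (`COc1cccc(/C=C/C(=O)/C=C/c2ccc(OCc3cn(CCCCCOc4cc(=O)oc5ccccc45)nn3)c(OC)c2)c1`): 37%
Compound 2 (`COc1ccc(/C=C/C(=O)/C=C/c2ccc(OCc3cn(CCOc4cc(=O)oc5ccccc45)nn3)c(OC)c2)cc1OC`): 90%

Of these two, compound 1 stands lowest, and compound 2 lies above it by a gap beyond the scatter. Compound 3 (`COc1cc(/C=C/C(=O)/C=C/c2ccccc2)ccc1OCc1cn(CCCCCOc2cc(=O)oc3ccccc23)nn1`) has not yet been measured. It differs from compound 1 by hydrogen in place of methoxy on an aromatic carbon, which turns 3-methoxyphenyl into phenyl. Going by the values given here, no measured pair shows this change, so no step beyond the scatter is expected in this assay in either direction. The estimated change is a number 3 percentage points higher from compound 1 to compound 3 (within the scatter), within the scatter. Compound 3 is expected at 40% (range 20% to 62%).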

Compound 3, percent growth inhibition at one concentration: 26%
For compound 3 the middle estimate is 14 percentage points above the measured one, within the range that was stated.
By their numbers in this assay, from the lowest: compound 3; then compound 1; then compound 2.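

In this assay, putting hydrogen in place of the methoxy of the 3-methoxyphenyl group gives a number 11 percentage points lower from compound 1 to compound 3 (beyond the scatter). The methoxy on this aromatic carbon therefore makes a modest difference to growth inhibition, and bare phenyl does not match it here. Nothing measured bears on why this step occurs.

Going by these compounds, whether a hydroxy group or an amine on this carbon would lie above or below compound 1 stays open. So does whether the same step would appear with the linking chain of compound 2.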